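The source may report more compounds than this note shows. Statements on the series, on what has been measured and on what is new or still open speak of the compounds shown alone.

Measured so far in a physicochemical assay for lipophilicity; on this read-out higher numbers stand for higher lipophilicity and lower numbers for lower lipophilicity:
- compound 1 `N[C@H]1CC[C@H](Nc2ccc3ncc(-c4cnc(Nc5ccccc5)nc4)n3n2)CC1`: 1.6
- compound 2 `Cc1ccc2ncc(-c3cnc(Nc4ncccc4F)nc3)n2n1`: 2.5

Of these two numbers, compound 2 has the higher, at 2.5. Compound 1 lies lower at 1.6, a gap beyond the usual scatter. The two compounds differ in more than one place, so that gap cannot be tied to any single change.

The next compound, compound 3 `CN1CC[C@H](Oc2ccc3ncc(-c4cnc(Nc5ncccc5F)nc4)n3n2)C1`, has not yet been measured. It is compound 2 with (1-methylpyrrolidin-3-yl)oxy in place of methyl on an aromatic carbon.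

Going by the values given here, no pair of measured compounds shows this change alone, so its size in this assay has to be judged. Among the compounds with values here, the only guide is compound 1, which also carries a larger group containing nitrogen on the shared core and stands at 1.6. On that weak evidence, a moderate fall somewhat beyond the scatter is expected. The expected step is a number 0.50 log units lower from compound 2 to compound 3 (beyond the scatter). For compound 3 the estimated value is 2, with an expected range from 1.5 to 2.5.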

Compound 3, distribution coefficient: 1.5
Compound 3: middle estimate off by 0.50 log units, on the high side; measured number inside the range.
By their numbers in this assay, from the lowest: compounds 3 and 1 (each within the scatter of the next); then compound 2.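

Going by these compounds alone, compound 2 and compound 3 give the first pair here that differs in one place, so the effect of a change at this aromatic carbon can now be read directly. In this assay, putting (1-methylpyrrolidin-3-yl)oxy in place of methyl gives a number 1.00 log units lower from compound 2 to compound 3 (beyond the scatter), and the number falls even though the entering group is much the larger of the two, so at least for this pair a bigger group did not bring a higher number. No measurement at hand shows which part of the new group accounts for the step.

The entering group brings an oxygen link, a five-membered ring, a ring nitrogen and a defined stereocentre all at once, and this single step cannot separate their shares. A plain methoxy group at the same carbon would test the oxygen link alone, while a cyclopentyloxy group would keep a five-membered ring without the nitrogen, and the mirror-image form of the pyrrolidine would show whether the stereocentre matters on this read-out.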